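The compounds below may be only part of what the source reports. "The series", "measured", "known", "first", "only" and "open" are said of these compounds alone.

Measured compounds:
compound 1 `O=C(O)CNc1nc(-c2ccccc2)nc2ccccc12` — 0%
compound 2 `C[C@H](Nc1nc(-c2ccccc2)nc2ccccc12)C(=O)O` — 9.3%
compound 3 `C[C@H](Nc1nc(-c2ccccc2)nc2ccc(Br)cc12)C(=O)O` — 0%

In a functional assay on the whole organism (strain Wistar) for inhibition, with Rattus norvegicus as the target, read by paw edema, at a dose of 100 mg/kg by the oral route (on this read-out higher numbers stand for more inhibition at the one dose given (going by the name of the read-out) and lower numbers for less inhibition), compound 2 holds the highest of the three numbers, but neither of its neighbours is separated from it beyond the scatter: a number 9.3 percentage points higher from compound 1 to compound 2 (within the scatter) and a number 9.3 percentage points lower from compound 2 to compound 3 (within the scatter). The next compound, compound 4 `CC[C@H](C)[C@H](Nc1nc(-c2ccccc2)nc2ccccc12)C(=O)O`, differs from compound 2 in one place: sec-butyl in place of methyl on a saturated chain carbon bound to a carbonyl carbon and a nitrogen on an aromatic ring. For the measured compounds named here, the only measured step at the same place is the one from compound 1 to compound 2, which stayed within the scatter, so no movement beyond the scatter is expected in this assay, and the expected step is a number 1.3 percentage points lower from compound 2 to compound 4 (within the scatter). Compound 4 is therefore estimated at 8%, with a range from 0% to 22%.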

Compound 4, a percentage reported as inhibition, in the whole organism at one dose (the size of the read-out at that dose, not a potency): 4.1%
Compound 4: middle estimate off by 3.9 percentage points, on the high side; measured number inside the range.
By their numbers in this assay, from the lowest: compounds 1, 3, 4 and 2 (each within the scatter of the next).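

In this assay, sec-butyl in place of methyl gives a number 5.2 percentage points lower from compound 2 to compound 4 (within the scatter) and sec-butyl in place of hydrogen gives a number 4.1 percentage points higher from compound 1 to compound 4 (within the scatter) at this saturated chain carbon bound to a carbonyl carbon and a nitrogen on an aromatic ring. This position thus carries hydrogen, methyl or the larger sec-butyl without any step leaving the scatter. The data offer no explanation for this result. Going by these compounds, whether a benzyl group, or a chain ending in an amine or a hydroxyl group, would move the number beyond the scatter remains open.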